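Fluoro for Bromo: Expected Growth Inhibition of Compound 4

The source may hold more compounds than are shown below. What is called first, only, known or untested is meant among the compounds shown, and "the series" means these compounds.

Measured compounds, in a functional assay on A549 cells (Homo sapiens) for inhibition, read by MTT assay, with a stated time of 48 h, tested at 10 uM; a higher number here means more inhibition of growth at the concentration tested, a lower number less inhibition of growth:
compound 1 `C#CCOc1ccc(/C=C/C(=O)c2ccc([N+](=O)[O-])cc2)cc1` gives 33%;
compound 2 `O=C(/C=C/c1ccc(OCc2cn(Cc3ccccc3)nn2)cc1)c1ccc(Br)cc1` gives 34%;
compound 3 `O=C(/C=C/c1ccc(OCc2cn(Cc3ccc(Br)cc3)nn2)cc1)c1ccc(Br)cc1` gives 27%.

Compound 3 stands lowest of the three numbers in this assay, but its gaps to compound 1 and to compound 2 are both within the scatter, so no order among them can be claimed. Compound 4 `O=C(/C=C/c1ccc(OCc2cn(Cc3ccc(F)cc3)nn2)cc1)c1ccc(Br)cc1` differs from compound 3 by fluoro in place of bromo on an aromatic carbon. Going by the values given here, the only measured step on this aromatic carbon is a number 7 percentage points lower from compound 2 to compound 3 (within the scatter), which did not move the number beyond the scatter. With bromo exchanged for fluoro at the same position, compound 4 is therefore expected to show no step beyond the scatter in this assay, namely a number 3 percentage points higher from compound 3 to compound 4 (within the scatter). Compound 4 is estimated at 30%, within 15% to 45%.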

Compound 4, percent growth inhibition at one concentration: 43%
Beside the measured number, compound 4's estimate is 13 percentage points below it; low and high end bracket the measured number.
By their numbers in this assay, from the lowest: compounds 3, 1, 2 and 4 (each within the scatter of the next, the first and the last beyond it).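

In this assay, going by these compounds alone, the change from 4-bromobenzyl to 4-fluorobenzyl gives a number 16 percentage points higher from compound 3 to compound 4 (beyond the scatter), the first step beyond the scatter at this position, so the two halogens on this aromatic carbon can be told apart. Hydrogen at the same carbon cannot be told apart from either halogen, with a number 9 percentage points higher from compound 2 to compound 4 (within the scatter) and a number 7 percentage points lower from compound 2 to compound 3 (within the scatter). No measurement at hand explains the difference between fluoro and bromo here. The compounds shown leave open how an amine or a carboxylic acid would read on this carbon, and whether the 4-bromophenyl to 4-fluorophenyl change would give a similar step.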